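The source may hold more compounds than are shown below. What is called first, only, known or untested is meant among the compounds shown, and "the series" means these compounds.

Working notes on an ADME assay on liver for metabolic stability, with Liver microsome (Rattus norvegicus) as the target, read by LC-MS, using microsomes, with a stated time of 5 h; a higher number here means faster removal of the compound, a lower number slower removal. Of the compounds shown here, three carry numbers so far. Compound 1 `O[C@H](c1ccccn1)[C@]1(c2cccc(OC(F)(F)F)c2)C[C@@H](O)C1` gives 217 mL/min/kg, second highest of the three and beyond the scatter from both of the others. Compound 3 `C[C@]1(O)C[C@](c2ccnc(C(F)(F)F)c2)([C@H](O)c2ccccn2)C1` lies lower at 83.3 mL/min/kg, and compound 2 `O[C@@]1(c2ccccn2)CC[C@@H](c2ccc(C(F)(F)F)cc2)C1` lies much higher at 2520 mL/min/kg.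

Still unmeasured is compound 4 `O[C@H](c1ccccn1)C1(c2cccc(OC(F)(F)F)c2)CCC1`, which keeps the rest of compound 1 and has hydrogen in place of hydroxy on a saturated ring carbon. The site is on the four-membered non-aromatic ring of carbon only.

Among the compounds with values here, no measured pair isolates this change, so the evidence is indirect. Compound 1 at 217 mL/min/kg and compound 3 at 83.3 mL/min/kg both have a hydroxy on the four-membered ring, while compound 2 at 2520 mL/min/kg has no such ring. That contrast is weak, since these compounds differ in several other places too. A rise in this assay is still the expected direction. The estimated step of a 3.0-fold higher number from compound 1 to compound 4 (0.48 log units; beyond the scatter) is expected to lie beyond the scatter, though the uncertainty is wide. Compound 4 is estimated at 650 mL/min/kg, with an expected range of 280 mL/min/kg to 1600 mL/min/kg.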

Compound 4, clearance: 1720 mL/min/kg
Estimate against measurement, compound 4: 2.6-fold (0.42 log units) below; measured number outside the range, above it.
By their numbers in this assay, from the lowest: compound 3; then compound 1; then compounds 4 and 2 (each within the scatter of the next).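

In this assay, within the data shown here, hydrogen in place of hydroxy on a saturated ring carbon gives a 7.9-fold higher number from compound 1 to compound 4 (0.90 log units; beyond the scatter) and provides the first reading of this change with the rest of compound 1 held fixed. Among these compounds, the site, two ring bonds from the ring atom that bears a hydroxy(pyridin-2-yl)methyl group, is therefore not silent in this read-out, since the hydroxy is the only difference within the pair. Nothing available explains why the number rises when the hydroxy leaves, and the reading rests on this single pair.

On these data alone, it remains open whether the rise is tied to the hydroxy itself or whether another group on the same ring carbon, such as a methoxy, an amine or a carboxylic acid, would hold the number nearer that of compound 1. Also open, as far as these compounds go, is whether the same change would give a step of similar size on the core of compound 3, which carries a methyl group and a hydroxy on its four-membered ring.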